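The source may hold more compounds than are shown below. What is called first, only, known or untested is meant among the compounds shown, and "the series" means these compounds.

Among the compounds with values here, compound 2 `O=C(Nc1nccs1)c1c(O)c2cccnc2n(-c2ccccc2)c1=O` stands lowest of the two numbers so far in a functional assay on the whole organism for inhibition, with Rattus norvegicus as the target, read by paw edema, at a dose of 100 mg/kg by the oral route; on this read-out higher numbers stand for more inhibition at the one dose given (going by the name of the read-out) and lower numbers for less inhibition: compound 2 gives 4.6%, whereas compound 1 `O=C(Nc1ccncc1)c1c(O)c2cccnc2n(-c2ccccc2)c1=O` gives 34.9%. Within the data shown here, the one measured step bears directly on the question: a number 30.3 percentage points lower from compound 1 to compound 2 (beyond the scatter). Compound 3 `Cc1cnccc1NC(=O)c1c(O)c2cccnc2n(-c2ccccc2)c1=O` is not yet measured; its change from compound 2 is 3-methylpyridin-4-yl in place of 1,3-thiazol-2-yl on an amide-type nitrogen. Among the measured compounds shown here, this reverses the measured step in kind, a six-membered aromatic ring with one hetero atom entering again on the amide-type nitrogen, now as 3-methylpyridin-4-yl rather than pyridin-4-yl, so a return toward the number of compound 1 is expected in this assay, upward and beyond the scatter, of roughly the size of the measured step; the added methyl has no measured counterpart, which widens the range. The estimate for compound 3 in this assay is 28%, between 10% and 45%. The expected step is a number 23.4 percentage points higher from compound 2 to compound 3 (beyond the scatter).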

Compound 3, a percentage reported as inhibition, in the whole organism at one dose (the size of the read-out at that dose, not a potency): 26.9%
For compound 3 the middle estimate is 1.1 percentage points above the measured one; low and high end bracket the measured number.
By their numbers in this assay, from the lowest: compound 2; then compounds 3 and 1 (each within the scatter of the next).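

In this assay, moving away from 1,3-thiazol-2-yl on the amide-type nitrogen gives a number 22.3 percentage points higher from compound 2 to compound 3 (beyond the scatter), so the recovery does not depend on unsubstituted pyridin-4-yl: a six-membered aromatic ring with one hetero atom that also carries a methyl serves as well. Methyl in place of hydrogen on an aromatic carbon of that ring gives a number 8 percentage points lower from compound 1 to compound 3 (within the scatter), so this added group brings no change that can be told from scatter. Nothing available explains either step.

On these data alone, it remains open whether a methoxy group or a chlorine atom in place of that methyl would hold the number, and whether a plain phenyl ring on the amide-type nitrogen would stay with the pyridine compounds or fall toward the thiazole. Readings at a single dose also leave any difference in potency open.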